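Ethoxy to Aminoamino on a Carbonyl Carbon

The source may report more compounds than this note shows. Statements on the series, on what has been measured and on what is new or still open speak of the compounds shown alone.

Within the data shown here, compound 1 `CCOC(=O)NC(c1ccccc1)c1ccc(Cl)cc1` is one of two compounds measured so far in a functional assay on SW-620 cells (Homo sapiens) for inhibition, read by MTT assay, with a stated time of 4 days; a lower number here means a stronger inhibitor, a higher number a weaker inhibitor. In this assay compound 1 gives only a limit, > 100000 nM, and not a number. The other measured compound, compound 2 `COc1ccc(/C(=N/NC(=O)NCCCC(C)Nc2cc(OC)cc3cccnc23)c2ccccc2)cc1`, likewise reaches only a limit in this assay, > 100000 nM. Among the measured compounds shown here, both values sit at the limit of > 100000 nM in this assay, at which 2 of the 2 values shown sit, so compound 1 cannot be placed above or below any partner, and no step between measured compounds exists. The unmeasured compound 3 `NNC(=O)NC(c1ccccc1)c1ccc(Cl)cc1` is compound 1 changed at one place: aminoamino in place of ethoxy on a carbonyl carbon. For the measured compounds named here, because both measured values rest at the limit of > 100000 nM in this assay, at which 2 of the 2 values shown sit, no measured step of any size is available to guide the expectation. The step is expected to be a number no higher from compound 1 to compound 3 (the limit leaves the size open), that is, none beyond the usual scatter, with a limit again the most likely outcome. Compound 3 is estimated at 100000 nM in this assay, within 30000 nM to 300000 nM.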

Compound 3, half-maximal inhibitory concentration: > 100000 nM
Compound 3: no number, only a limit; the forecaster's own chance of this, stated with the estimate: 80%; the middle value sits exactly at the limit.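

In this assay compound 3 gives > 100000 nM, a limit and not a number. No step can be read from compound 1 to compound 3: the limit of > 100000 nM in this assay, at which 3 of the 3 values shown sit. The compounds shown leave open whether aminoamino in place of ethoxy on a carbonyl carbon changes inhibition at all.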